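The compounds below may be only part of what the source reports. "The series", "measured", "known", "first", "only" and "open" are said of these compounds alone.

Measured compounds in a functional assay on SiHa cells (Homo sapiens) for inhibition, read by CCK-8 assay, with a stated time of 72 h, tested at 10 uM; on this read-out higher numbers stand for more inhibition of growth at the one concentration tested and lower numbers for less inhibition of growth:
compound 1 `CN(C)C(=O)c1cc2cnc(Nc3ccc(NC(=O)C4(C(=O)Nc5ccccc5)CC4)cc3)nc2n1C1CCCC1` gives 106%
compound 2 `CN(C)C(=O)c1cc2cnc(Nc3ccc(NC(=O)C4(C(=O)Nc5cccc(O)c5)CC4)cc3)nc2n1C1CCCC1` gives 75.7%
compound 3 `CN(C)C(=O)c1cc2cnc(Nc3ccc(NC(=O)C4(C(=O)Nc5ccc(Br)cc5)CC4)cc3)nc2n1C1CCCC1` gives 98.8%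

Compound 1 stands highest of the three numbers in this assay, though compound 3 lies within the scatter of it, with a number 7.2 percentage points lower from compound 1 to compound 3 (within the scatter). Compound 2 lies well apart, with a number 30.3 percentage points lower from compound 1 to compound 2 (beyond the scatter), and between compound 2 and compound 3 the step is a number 23.1 percentage points higher from compound 2 to compound 3 (beyond the scatter).

Compound 4 `CN(C)C(=O)c1cc2cnc(Nc3ccc(NC(=O)C4(C(=O)Nc5cccc(Cl)c5)CC4)cc3)nc2n1C1CCCC1` has not been measured. It differs from compound 1 by chloro in place of hydrogen on an aromatic carbon. Within the data shown here, two measured steps bear on this change. The bromo in place of hydrogen on an aromatic carbon, from compound 1 to compound 3, moved the number only within the scatter. The hydroxy in place of hydrogen on an aromatic carbon, from compound 1 to compound 2, moved it beyond the scatter. A chloro is a halogen like bromo and carries no hydrogen-bond donor, so the expectation for compound 4 is a step of a number 9 percentage points lower from compound 1 to compound 4 (within the scatter), at most a small loss. Compound 4 is therefore expected at 97%, with a range from 82% to 106%.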

Compound 4, percent growth inhibition at one concentration: 97.3%
For compound 4 the middle estimate is 0.3 percentage points below the measured one; measured number inside the range.
By their numbers in this assay, from the lowest: compound 2; then compounds 4, 3 and 1 (each within the scatter of the next).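

In this assay, the change to 3-chlorophenyl gives a number 8.7 percentage points lower from compound 1 to compound 4 (within the scatter), while chloro in place of the hydroxy of the 3-hydroxyphenyl group gives a number 21.6 percentage points higher from compound 2 to compound 4 (beyond the scatter). The loss seen with hydroxy is therefore not shared by every group at this place on the ring, so compound 2 stands alone among the substituted compounds shown. The 3-chlorophenyl and 4-bromophenyl groups also stay together, with a number 1.5 percentage points lower from compound 3 to compound 4 (within the scatter), and nothing available explains why chloro and hydroxy part here.

Going by these compounds, whether an amine, a methoxy group or a carboxylic acid at this place would track the chloro or the hydroxy remains open. Because the two halogens differ in both identity and ring place, the compounds shown also cannot separate those two changes, which a 3-bromophenyl or 4-chlorophenyl group would address.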